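Permeability of a methylpyrazinyl urea in MDCKII-LE cells

The source may report more compounds than this note shows. Statements on the series, on what has been measured and on what is new or still open speak of the compounds shown alone.

Measured compounds:
compound 1, `O=C(N1CCC(c2ccccc2)CC1)N(c1nccc2ccccc12)[C@@H]1CCCNC1`, 3.9 10^-6 cm/s
compound 2, `Cn1ccc2ccnc(N(C(=O)N3CCC(c4ccccc4)CC3)[C@@H]3CCCNC3)c21`, 5.2 10^-6 cm/s
compound 3, `Cc1cccnc1N(C(=O)N1CCC(c2cnn3cccnc23)CC1)[C@@H]1CCCNC1`, 1.8 10^-6 cm/s

Three ureas built on a shared core have been measured in an ADME assay on MDCKII-LE cells (Canis lupus familiaris) for permeability, with a stated time of 1.5 h; on this read-out lower numbers stand for lower permeability and higher numbers for higher permeability. Compound 2 holds the highest number of the three, but its nearest neighbour compound 1 sits only a 1.3-fold higher number from compound 1 to compound 2 (0.12 log units; within the scatter), which is within the scatter; compound 3, which differs from compound 2 in two places, gives the lowest number.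

Compound 4 is `Cc1nccnc1N(C(=O)N1CCC(c2ccccc2)CC1)[C@@H]1CCCNC1`. It is obtained from compound 2 by a group of 7 heavy atoms (5 carbon, 2 nitrogen; one six-membered aromatic ring with 2 hetero atoms) in place of a group of 10 heavy atoms (8 carbon, 2 nitrogen; one five-membered aromatic ring with 1 hetero atom, one six-membered aromatic ring with 1 hetero atom), on an amide-type nitrogen.

Among the compounds with values here, one measured step bears on this change: the exchange of the aromatic group on the amide-type nitrogen between compound 1 and compound 2, which gave a 1.3-fold higher number from compound 1 to compound 2 (0.12 log units; within the scatter), a move inside the scatter. That step suggests that swapping the aromatic group on this nitrogen shifts this assay little. Compound 3, which carries a smaller six-membered aromatic group on the same nitrogen, shows a lower number, but it also differs in the group on the piperidine, so its value is only a weak pointer.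

Compound 4 is therefore expected to land somewhat lower than compound 2, with a step of a 2.0-fold lower number from compound 2 to compound 4 (0.30 log units; within the scatter), at the edge of the scatter. The estimate for compound 4 in this assay is 2.6 10^-6 cm/s, with a range from 1.2 10^-6 cm/s to 5.5 10^-6 cm/s.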

Compound 4, apparent permeability in the MDCKII-LE assay: 11.5 10^-6 cm/s
Compound 4: the middle estimate sits 4.4-fold (0.65 log units) below what was measured, outside the stated range (above it).
By their numbers in the MDCKII-LE assay, from the lowest: compound 3; then compounds 1 and 2 (each within the scatter of the next); then compound 4.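

In the MDCKII-LE assay, the 3-methylpyrazin-2-yl group on the amide-type nitrogen gives steps beyond the scatter, a 2.2-fold higher number from compound 2 to compound 4 (0.34 log units; beyond the scatter) and a 2.9-fold higher number from compound 1 to compound 4 (0.47 log units; beyond the scatter), so this position can move the read-out, which the earlier exchange on this nitrogen had not shown. In a physicochemical assay for lipophilicity, using the shake flask method (on this read-out higher numbers stand for higher lipophilicity and lower numbers for lower lipophilicity), compound 2 gives 1.4 and compound 4 gives 0.3, a change of a number 1.10 log units lower from compound 2 to compound 4 (beyond the scatter). In this pair, the higher permeability therefore came with lower measured lipophilicity: the measured distribution coefficient of compound 2, 1.4, and of compound 4, 0.3, a number 1.10 log units lower (beyond the scatter)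

The compounds shown do not tell whether the methyl group of 3-methylpyrazin-2-yl matters, or how an ethyl or a methoxy group in its place would read in the MDCKII-LE assay. They also leave open whether the same exchange would hold with the group on the piperidine of compound 3.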